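A few compounds are considered here, and "the series" means these few. Any claim that something is new, unique, unknown or untested is made for them only; others in the source may bear on it.

Of the compounds shown here, three built on a shared core have been tested in a functional assay on NCI-H322M cells (Homo sapiens) for inhibition, read by sulforhodamine B assay, with a stated time of 48 h; on this read-out lower numbers stand for stronger inhibition of growth and higher numbers for weaker inhibition of growth. Compound 1 `COc1cc(-c2nn(-c3cccc(NC(=O)Nc4cc(C(F)(F)F)cc(C(F)(F)F)c4)c3)cc2-c2ccncc2)ccc1Cl` gives 1020 nM. Compound 3 `O=C(Nc1cccc(-n2cc(-c3ccncc3)c(-c3ccc(Cl)c(O)c3)n2)c1)Nc1cc(C(F)(F)F)cc(C(F)(F)F)c1` gives 1310 nM, and the step of a 1.3-fold higher number from compound 1 to compound 3 (0.11 log units; within the scatter) came with a hydrogen in place of methyl on an oxygen on an aromatic ring. Compound 2 `COc1cc(-c2nn(-c3cccc(NC(=O)c4cccc(C(F)(F)F)c4)c3)cc2-c2ccncc2)ccc1Cl` gives 10800 nM, the highest of the three numbers. Compound 4 `COc1cc(-c2nn(-c3cccc(NC(=O)Nc4ccc(Cl)c(C(F)(F)F)c4)c3)cc2-c2ccncc2)ccc1Cl` differs from compound 2 by (4-chloro-3-(trifluoromethyl)phenyl)amino in place of 3-(trifluoromethyl)phenyl on a carbonyl carbon. Within the data shown here, no measured step covers this exact change, but compound 1 carries a urea where compound 2 carries an amide, and their two values lie far apart. Compound 4, which also carries a urea, is therefore expected to give a much lower number, estimated as a 7.2-fold lower number from compound 2 to compound 4 (0.86 log units; beyond the scatter). Compound 4 is estimated at 1500 nM, with a range from 500 nM to 5000 nM.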

Compound 4, concentration for 50% growth inhibition: 1500 nM
Estimate against measurement, compound 4: no gap at the digits printed, within the range that was stated.
By their numbers in this assay, from the lowest: compounds 1, 3 and 4 (each within the scatter of the next); then compound 2.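

In this assay the step on this carbonyl carbon, (4-chloro-3-(trifluoromethyl)phenyl)amino in place of 3-(trifluoromethyl)phenyl, gives a 7.2-fold lower number from compound 2 to compound 4 (0.86 log units; beyond the scatter) and lies beyond the scatter. Among these compounds, it is the first measured step at this position, and it places compound 4 with compounds 1 and 3, each within the scatter of the next. No available evidence accounts for this step. The compounds shown do not separate the entering amino nitrogen from the entering chlorine. On these data alone, how a nitrile or a methyl group in place of that chlorine would read also stays open.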